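Taking the Nitro Group Off Compound 1

The compounds below may be only part of what the source reports. "The series", "measured", "known", "first", "only" and "open" are said of these compounds alone.

Compound 1 `CCCCc1ccc(C(=O)/C=C/c2ccc([N+](=O)[O-])o2)cc1`: 41200 nM
Compound 2 `O=C(/C=C/c1ccc([N+](=O)[O-])o1)c1ccc(N2CCNCC2)cc1`: 44300 nM

Both values come from an ADME assay on cells (Astrocyte, Rattus norvegicus, strain Wistar) for inhibition, read by sulforhodamine B assay, with a stated time of 72 h (on this read-out higher numbers stand for lower toxicity in this test and lower numbers for higher toxicity in this test), where compound 1 and compound 2 stand level. Among the measured compounds shown here, the only measured step, a 1.1-fold higher number from compound 1 to compound 2 (0.03 log units; within the scatter), puts piperazin-1-yl in place of butyl and leaves the nitro untouched, so it gives no measure of the change at hand. Compound 3 `CCCCc1ccc(C(=O)/C=C/c2ccco2)cc1` differs from compound 1 by hydrogen in place of nitro on an aromatic carbon. With no measured guide, no shift beyond the scatter is expected, and the expected step is a 1.5-fold higher number from compound 1 to compound 3 (0.16 log units; within the scatter). Compound 3 is estimated at 60000 nM, within a wide range from 20000 nM to 180000 nM.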

Compound 3, half-maximal cytotoxic concentration: > 100000 nM
Compound 3 was reported as a limit; the forecaster's own chance of this, stated with the estimate: 25%; middle value at least 1.6-fold (0.22 log units) from the limit.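

Hydrogen in place of nitro, on the aromatic carbon next to the ring oxygen, gives an at least 2.4-fold higher number from compound 1 to compound 3 (0.38 log units; beyond the scatter) in this assay. The earlier step, at the butyl end of the molecule, stayed within the scatter, so this is the first change shown to move the number beyond it, towards lower toxicity in this test. The value of compound 3 is a limit and not a number: the limit of > 100000 nM in this assay, at which 1 of the 3 values shown sits.

Going by these compounds, it remains open whether the same step holds when piperazin-1-yl replaces butyl. Also open, on these data alone, is what a nitrile or a carboxylic acid on that carbon would give.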